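Fluoro to methoxy on the hydroxy compound

The source may report more compounds than this note shows. Statements on the series, on what has been measured and on what is new or still open speak of the compounds shown alone.

Measured so far:
compound 1 `Fc1ccc(-c2ccc(-c3ccc(-c4nc5ccccc5[nH]4)cc3)cc2)cc1`: 36200 nM
compound 2 `Oc1cccc2[nH]c(-c3ccc(-c4ccc(-c5ccc(F)cc5)cc4)cc3)nc12`: 3010 nM

In a functional assay on MCF7 cells (Homo sapiens) for inhibition, read by sulforhodamine B assay (a lower number here means a stronger inhibitor of growth, a higher number a weaker inhibitor of growth), compound 2 `Oc1cccc2[nH]c(-c3ccc(-c4ccc(-c5ccc(F)cc5)cc4)cc3)nc12` gives the lower of the two numbers (3010 nM). Compound 3 `COc1ccc(-c2ccc(-c3ccc(-c4nc5c(O)cccc5[nH]4)cc3)cc2)cc1` carries methoxy in place of fluoro on an aromatic carbon, para to a large group (methoxy in place of fluoro on an aromatic carbon). For the measured compounds named here, the only measured step, a 12-fold lower number from compound 1 to compound 2 (1.08 log units; beyond the scatter), is large, but it is hydroxy in place of hydrogen, a different change. Going by the values given here, no measured step covers fluoro to methoxy, so no change beyond the scatter is expected (a 1.0-fold lower number from compound 2 to compound 3 (0.00 log units; within the scatter)). The estimated value for compound 3 is 3000 nM (expected range 900 nM to 10000 nM).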

Compound 3, concentration for 50% growth inhibition: 3110 nM
Compound 3: middle estimate off by 1.0-fold (0.02 log units), on the low side, and the stated range covers the measured number.
By their numbers in this assay, from the lowest: compounds 2 and 3 (each within the scatter of the next); then compound 1.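

In this assay, 4-fluorophenyl to 4-methoxyphenyl on the hydroxy compound gives (a 1.0-fold higher number from compound 2 to compound 3 (0.01 log units; within the scatter)), so this aromatic carbon, para to a large group, takes methoxy in place of fluoro with no change beyond the scatter. The earlier step showed only the effect of the hydroxy on the core, not any reading at this outer position. No evidence bearing on this result is at hand.

As far as these compounds go, whether an amine or a carboxylic acid is also accepted here remains open. So does whether the same flat reading holds on the core of compound 1, which lacks the hydroxy.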